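A few compounds are considered here, and "the series" means these few. Any claim that something is new, unique, unknown or untested is made for them only; others in the source may bear on it.

Measured compounds:
compound 1, `O=C(COc1ccc(C(=O)/C=C/c2cccc(Cl)c2)cc1)N[C@H]1CCOC1=O`, 4990 nM
compound 2, `Cc1ccc(C(C)C)c(OCCSC(=S)N[C@H]2CCOC2=O)c1`, > 64000 nM
compound 3, `O=C1OCC[C@@H]1NC(=S)SCCOc1cccc2ccccc12`, > 64000 nM

In a functional assay on PC-3 cells (Homo sapiens) for antiproliferative activity, read by MTT assay, with a stated time of 72 h (on this read-out higher numbers stand for weaker inhibition and lower numbers for stronger inhibition), compound 1 gives 4990 nM, and this is the only number shown among the three measured compounds. In this assay compound 2 gives > 64000 nM, which is a limit of the assay and not a number. In this assay compound 3 gives > 64000 nM, likewise a limit and not a number. For the measured compounds named here, two of the three values therefore sit at the limit of > 64000 nM in this assay, at which 2 of the 3 values shown sit, so compound 1 stands alone as the one compound with a measured inhibitory concentration, and no step between measured compounds can be stated.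

The next compound, compound 4, `O=C(COc1ccc(C(=O)/C=C/c2cccc(F)c2)cc1)N[C@H]1CCOC1=O`, shares the core of compound 1 and differs from it in one place: fluoro in place of chloro on an aromatic carbon. No measured step of this kind is shown here. Compound 4 is expected to stay close to compound 1, with a step from compound 1 to compound 4 of a 1.3-fold higher number from compound 1 to compound 4 (0.11 log units; within the scatter), which is not expected to exceed the usual scatter. Compound 4 is thus estimated at 6500 nM, with a range from 2500 nM to 18000 nM.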

Compound 4, half-maximal inhibitory concentration: 23200 nM
Estimate against measurement, compound 4: 3.6-fold (0.55 log units) below; the whole stated range lies below it.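

In this assay the exchange of chloro for fluoro gives a 4.6-fold higher number from compound 1 to compound 4 (0.67 log units; beyond the scatter) and so offers the first readable step among these compounds. It shows that this place on the aromatic ring responds to a change of one halogen for another, even though the count of heavy atoms, hydrogen-bond donors, hydrogen-bond acceptors and net charge stays the same, and that chloro is the better of the two here. No measured property shown here accounts for this step.

The compounds shown leave open whether bromo, methyl, methoxy or plain hydrogen at this place would extend the trend or break it. They also leave open whether the difference between chloro and fluoro would persist with either halogen elsewhere on the ring.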